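This account rests on a few compounds, and the source may have more. Where it says the series, first, only, none or still open, it means among the compounds named here.

Values measured so far in a physicochemical assay for solubility, read by LC-MS, in phosphate buffer, with a stated time of 24 h, at pH 7.4 (a higher number here means a more soluble compound, a lower number a less soluble compound), are:
compound 1 `Cc1nc(CO)ccc1-c1cnc(NCc2c(F)ccc3c2CCO3)c2cn[nH]c(=O)c12` gives 3000 nM
compound 2 `CN(C)Cc1ccc(C(=O)Nc2cnc(NCc3c(F)ccc4c3CCO4)n3cnnc23)cc1` gives 520000 nM

Compound 1 holds the lower of these two numbers, and compound 2 lies far above it, well beyond the usual scatter of repeated measurements. The next compound to be measured is compound 3 `CN(C)C(=O)c1cc(-c2cnc(NCc3c(F)ccc4c3CCO4)c3cn[nH]c(=O)c23)n(C)n1`, which keeps the core of compound 1 and exchanges one group: 3-(dimethylcarbamoyl)-1-methyl-1H-pyrazol-5-yl in place of 6-(hydroxymethyl)-2-methylpyridin-3-yl on an aromatic carbon. Among the measured compounds shown here, the two measured compounds are not linked by a change in one place, so no measured step shows how such an exchange moves the numbers in this assay. For the measured compounds named here, with only this to go on, the expectation stays near compound 1 (3000 nM), leaning slightly upward, with no step clearly beyond the scatter. The estimated step is small: a 1.7-fold higher number from compound 1 to compound 3 (0.22 log units; within the scatter). For compound 3 the expected value is 5000 nM, with an estimated range from 1000 nM to 30000 nM.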

Compound 3, solubility: 3000 nM
Compound 3: middle estimate off by 1.7-fold (0.22 log units), on the high side, and the stated range covers the measured number.
By their numbers in this assay, from the lowest: compounds 1 and 3 (each within the scatter of the next); then compound 2.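

Among the compounds shown here, this is the first step in this assay that isolates a single place, the aromatic carbon para to a large group on the shared core, and it reads no change at the digits printed from compound 1 to compound 3 (within the scatter). It shows that this position can take quite different groups with no step beyond the scatter: 6-(hydroxymethyl)-2-methylpyridin-3-yl has a six-membered aromatic ring and 1 hydrogen-bond donor, while 3-(dimethylcarbamoyl)-1-methyl-1H-pyrazol-5-yl has a five-membered aromatic ring, 0 hydrogen-bond donors and 3 hydrogen-bond acceptors, so these differences in ring size and donor count did not show up as a separate number here. No supporting measurement accompanies this result that would explain it.

This single exchange cannot show whether the position is insensitive in general or whether these two groups simply happen to give matching numbers, and a carboxylic acid or a primary amine on this aromatic carbon remains an open test. Compound 1 and compound 3 differ from compound 2 in more than one place, so what separates the much higher number of compound 2, 520000 nM, from theirs cannot be traced to any one change.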